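Swapping a dimethoxyphenyl for a furan ring on the shared core

This account rests on a few compounds, and the source may have more. Where it says the series, first, only, none or still open, it means among the compounds named here.

Of the compounds shown here, three built on one core have been measured in a functional assay for inhibition, tested at 20 ug/mL; a higher number here means a stronger effect of the compound at the concentration tested, a lower number a weaker effect. Compound 1, `Cc1cc(O)c(C(C)C)cc1-c1cc(-c2cccs2)c(C#N)c(=O)[nH]1`, carries a thiophen-2-yl group and gives 26% in this assay. Compound 2, `COc1ccc(-c2cc(-c3cc(C(C)C)c(O)cc3C)[nH]c(=O)c2C#N)c(OC)c1`, carries a 2,4-dimethoxyphenyl group at the same place and gives 27% in this assay. Compound 3, `COc1cc(OC)c(-c2cc(-c3cc(C(C)C)c(O)cc3C)[nH]c(=O)c2C#N)c(OC)c1`, adds a further methoxy group and gives 32% in this assay. Compound 2 thus stands second of the three numbers, with compound 1 closest and compound 3 furthest, and both of its neighbours lie within the scatter of it.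

Compound 4, `Cc1cc(O)c(C(C)C)cc1-c1cc(-c2ccco2)c(C#N)c(=O)[nH]1`, has not yet been measured. It differs from compound 2 in one place: furan-2-yl in place of 2,4-dimethoxyphenyl on an aromatic carbon.

The step that bears most on this change is the one from thiophen-2-yl to 2,4-dimethoxyphenyl, which gave a number 1 percentage points higher from compound 1 to compound 2 (within the scatter). The step from compound 2 to compound 3 gave a number 5 percentage points higher from compound 2 to compound 3 (within the scatter). Neither change at this position moved the read-out beyond the scatter, so a five-membered aromatic ring with one hetero atom in place of the 2,4-dimethoxyphenyl is expected to give no step beyond the scatter either, a number 1 percentage points lower from compound 2 to compound 4 (within the scatter). Compound 4 is therefore estimated at 26% in this assay, with a range from 15% to 37%.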

Compound 4, a percentage reported as inhibition, at one concentration (the size of the read-out at that concentration, not a potency): 26%
Compound 4: the middle estimate sits on the measured number at the digits printed; the range from low to high includes it.
By their numbers in this assay, from the lowest: compounds 1, 4, 2 and 3 (each within the scatter of the next).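

Compound 4 shows that this place, opposite the ring nitrogen and ortho to the cyano group, can take a much smaller ring without the read-out leaving the scatter. In this assay, going by these compounds alone, furan-2-yl with 5 heavy atoms replaces 2,4-dimethoxyphenyl with 10 heavy atoms and gives a number 1 percentage points lower from compound 2 to compound 4 (within the scatter), so the earlier steps among larger or sulfur-bearing rings now gain a five-membered ring with an oxygen atom and a much smaller group. The exchange of thiophen-2-yl for furan-2-yl gives no change at the digits printed from compound 1 to compound 4 (within the scatter), which adds that a change of hetero atom within a five-membered aromatic ring leaves this assay within the scatter in this pair. No measurement is given that would explain why these groups read alike.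

Every group shown at this place is an aromatic ring, so what a saturated ring such as piperidine, an amine, a carboxylic acid or a longer alkyl chain would do there stays open. The read-outs also come from one concentration, so whether compounds that read alike there would also match in potency cannot be told.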